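Adding a Second Pentyl Further Along the Chain

The compounds below may be only part of what the source reports. "The series", "measured", "known", "first", "only" and "open" are said of these compounds alone.

Compound 2 `CCCCCCC(=O)Nc1ccn([C@@H]2CO[C@H](CO)O2)c(=O)n1` holds the lower of the two numbers seen so far in a functional assay on A549 cells (Homo sapiens) for cytotoxicity, read by sulforhodamine B assay, with a stated time of 72 h (on this read-out higher numbers stand for weaker inhibition and lower numbers for stronger inhibition), where compound 2 gives 1040 nM while compound 1 `CC(=O)Nc1ccn([C@@H]2CO[C@H](CO)O2)c(=O)n1` gives 6870 nM. Among the compounds with values here, the only measured step, a 6.6-fold lower number from compound 1 to compound 2 (0.82 log units; beyond the scatter), came from pentyl in place of hydrogen. Compound 3 `CCCCCCCCCCCC(=O)Nc1ccn([C@@H]2CO[C@H](CO)O2)c(=O)n1` repeats that type of change: pentyl in place of hydrogen on a saturated chain carbon, six bonds along the chain from a carbonyl carbon. Because the earlier step of a 6.6-fold lower number from compound 1 to compound 2 (0.82 log units; beyond the scatter) was modest and beyond the scatter, a further fall in this assay is expected, though likely a smaller one. Compound 3 is estimated at 400 nM, within 120 nM to 1500 nM, meaning an expected step of a 2.6-fold lower number from compound 2 to compound 3 (0.41 log units; beyond the scatter).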

Compound 3, half-maximal inhibitory concentration: 15 nM
The estimate for compound 3 lay 27-fold (1.43 log units) above the measured number, outside the stated range (below it).
By their numbers in this assay, from the lowest: compound 3; then compound 2; then compound 1.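

In this assay, the repeated change did not bring a smaller gain: pentyl in place of hydrogen, six bonds along the chain from a carbonyl carbon, gave a 69-fold lower number from compound 2 to compound 3 (1.84 log units; beyond the scatter) and so exceeded the earlier 6.6-fold lower number from compound 1 to compound 2 (0.82 log units; beyond the scatter) in size. The same added group can therefore count for far more at this further place on the chain, and all three compounds fit the fall with chain length. No available evidence accounts for the size of this step. Still open, as far as these compounds go, is whether a longer chain would lower the number further or reverse the trend. Also open, from the compounds shown here alone, is whether an amine or a carboxylic acid at the chain end would keep this gain.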